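The compounds below may be only part of what the source reports. "The series", "measured", "known", "first", "only" and "open" are said of these compounds alone.

Of the compounds shown here, three from one series have been tested in an ADME assay on HepG2 cells (Homo sapiens) for cytotoxicity, read by luminescence, CellTiter-Glo and ATP content, with a stated time of 72 h; a higher number here means that more compound is needed for the effect, a lower number that less compound is needed. All share a core with a three-carbon chain joining two amine nitrogens; they differ in the group on the aromatic carbon of the core and in the group on the chain carbon next to the outer amine.

Compound 1, `COc1ccc(-c2ccc3c(NCCCNCc4cccc(OC)c4O)ccnc3c2)cc1`, gives 1600 nM. Compound 2, `COc1cccc(CNCCCNc2ccnc3cc(Cc4cccc(C(F)(F)F)c4)ccc23)c1O`, gives 1720 nM. Compound 3, `COc1ccc(-c2ccc3c(NCCCNCc4cc(F)ccc4OC)ccnc3c2)cc1`, gives 5960 nM.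

Two changes connect these. From compound 1 to compound 2 the change is 3-(trifluoromethyl)benzyl in place of 4-methoxyphenyl on an aromatic carbon; the step is a 1.1-fold higher number from compound 1 to compound 2 (0.03 log units; within the scatter). From compound 1 to compound 3 the change is 5-fluoro-2-methoxyphenyl in place of 2-hydroxy-3-methoxyphenyl on a saturated chain carbon bound to an amine nitrogen; the step is a 3.7-fold higher number from compound 1 to compound 3 (0.57 log units; beyond the scatter), so compound 3 stands apart from the other two.

Compound 4, `COc1ccc(F)cc1CNCCCNc1ccnc2cc(Cc3cccc(C(F)(F)F)c3)ccc12`, has not yet been measured. It differs from compound 3 by 3-(trifluoromethyl)benzyl in place of 4-methoxyphenyl on an aromatic carbon. This is the same change as that from compound 1 to compound 2, made at the same place and with the same groups leaving and entering; only the group on the chain carbon differs between the two pairs, as described above for compound 1 and compound 3.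

Because a 1.1-fold higher number from compound 1 to compound 2 (0.03 log units; within the scatter) was a small step, a similar step is expected here, and the estimated change from compound 3 to compound 4 is a 1.1-fold higher number from compound 3 to compound 4 (0.02 log units; within the scatter). Compound 4 is therefore expected to give about 6300 nM, with a likely range from 3000 nM to 13000 nM. Whether the measurement confirms this remains to be seen.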

Compound 4, half-maximal effective concentration: 440 nM
For compound 4 the middle estimate is 14-fold (1.16 log units) above the measured one, and the stated range ends above it.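

In this assay, placing 3-(trifluoromethyl)benzyl in place of 4-methoxyphenyl on the aromatic carbon now gives a 14-fold lower number from compound 3 to compound 4 (1.13 log units; beyond the scatter), so this change does not carry over unchanged from one core to the other: the same change on two cores in this assay, a 1.1-fold higher number (0.03 log units; within the scatter) from compound 1 to compound 2 and a 14-fold lower number (1.13 log units; beyond the scatter) from compound 3 to compound 4, 15-fold (1.16 log units) apart, beyond the scatter of two such steps.

The second change, 5-fluoro-2-methoxyphenyl in place of 2-hydroxy-3-methoxyphenyl on the chain carbon, gives a 3.9-fold lower number from compound 2 to compound 4 (0.59 log units; beyond the scatter), whereas with 4-methoxyphenyl on the aromatic carbon its step ran the opposite way: the same change on two cores in this assay, a 3.7-fold higher number (0.57 log units; beyond the scatter) from compound 1 to compound 3 and a 3.9-fold lower number (0.59 log units; beyond the scatter) from compound 2 to compound 4, 15-fold (1.16 log units) apart, beyond the scatter of two such steps.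

These two comparisons are one observation seen from both sides: across these four compounds, the effect of changing one group depends on the other group present, but the data do not show why this happens or whether it extends beyond these compounds.

The compounds shown leave open whether the same dependence would appear with a plain benzyl or a chlorine on the aromatic carbon, or with a longer chain joining the two amine nitrogens. They also leave open whether a similar dependence would appear in a different cell type.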